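Cytotoxicity notes: carboxymethoxy to methoxy in the amide series

A few compounds are considered here, and "the series" means these few. Any claim that something is new, unique, unknown or untested is made for them only; others in the source may bear on it.

For the measured compounds named here, compound 1 `O=C(O)COc1cc(Cl)c(C(=O)Nc2cccc(-c3nc4ccccc4s3)c2)cc1[N+](=O)[O-]` is one of two compounds measured in an ADME assay on Raji cells (Homo sapiens) for cytotoxicity, with a stated time of 72 h; a lower number here means that less compound is needed, a higher number that more compound is needed for the effect. In this assay compound 1 gives only the limit > 25000 nM and no number, as shown by the limit of > 25000 nM in this assay, at which 1 of the 2 values shown sits. Compound 2 `O=C(Nc1ccc(-c2ccccc2)cc1)c1cc([N+](=O)[O-])ccc1Cl` likewise gives only the limit > 27000 nM in this assay, as shown by the limit of > 27000 nM in this assay, at which 1 of the 2 values shown sits. Compound 3 `COc1cc(Cl)c(C(=O)Nc2cccc(-c3nc4ccccc4s3)c2)cc1[N+](=O)[O-]` differs from compound 1 by hydrogen in place of carboxy on a saturated chain carbon bound to an oxygen on an aromatic ring. Going by the values given here, no measured step covers this change, and both values recorded so far are limits, so no step beyond the usual scatter is expected in this assay. Compound 3 is expected to give about 25000 nM in this assay, within 10000 nM to 60000 nM. The step of a number no higher from compound 1 to compound 3 (the limit leaves the size open) is an estimate only and most likely another limit.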

Compound 3, half-maximal effective concentration: > 25000 nM
Compound 3: no number, only a limit; the forecaster's own chance of this, stated with the estimate: 70%; the middle value lies on the limit itself.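

Compound 1 and compound 3 both give only limits in this assay, so the step between them cannot be read. The compounds shown leave open whether carboxymethoxy to methoxy changes the half-maximal effective concentration at all.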